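Swapping a formylphenyl group for a chlorophenylsulfanyl group

This account rests on a few compounds, and the source may have more. Where it says the series, first, only, none or still open, it means among the compounds named here.

Measured so far in an ADME assay on HEL cells (Homo sapiens) for cytotoxicity, with a stated time of 3 days; on this read-out higher numbers stand for lower toxicity in this test and lower numbers for higher toxicity in this test:
compound 1, `Cc1cc(-c2ccc(C=O)cc2)cn2c(CSCCc3ccccc3)cnc12`, 100 ug/mL
compound 2, `Cc1cc(N2CCCC2=O)cn2c(CSCCc3ccccc3)cnc12`, > 100 ug/mL

Among the compounds with values here, compound 1 gives the only plain number in this assay, 100 ug/mL, while for compound 2 the assay reports only a limit, > 100 ug/mL. Within the data shown here, the one measured step, a number no lower from compound 1 to compound 2 (the limit leaves the size open), therefore has no readable size; it rests on (the limit of > 100 ug/mL in this assay, at which 1 of the 2 values shown sits).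

Compound 3, `Cc1cc(Sc2ccc(Cl)cc2)cn2c(CSCCc3ccccc3)cnc12`, differs from compound 1 in one place: (4-chlorophenyl)sulfanyl in place of 4-formylphenyl on an aromatic carbon. Among the measured compounds shown here, no measured step covers this change, and the step from compound 1 to compound 2 concerns a different group, so nothing here tells what this swap does in this assay. The expectation is therefore that compound 3 stays close to compound 1, with no change at the digits printed from compound 1 to compound 3 (within the scatter) within the usual scatter. Compound 3 is estimated at 100 ug/mL, with a range from 30 ug/mL to 100 ug/mL.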

Compound 3, minimum cytotoxic concentration: 20 ug/mL
Beside the measured number, compound 3's estimate is 5.0-fold (0.70 log units) above it, outside the stated range (below it).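

In this assay, the group on this aromatic carbon clearly matters, and the two groups involved count the same heavy atoms and one aromatic ring each: (4-chlorophenyl)sulfanyl in place of 4-formylphenyl gives a 5.0-fold lower number from compound 1 to compound 3 (0.70 log units; beyond the scatter). The same group in place of 2-oxopyrrolidin-1-yl gives an at least 5.0-fold lower number from compound 2 to compound 3 (0.69 log units; beyond the scatter), so compound 3 shows the highest toxicity in this test of the three compounds. The value of compound 2 is a limit, which leaves the upper size of that second step open: the limit of > 100 ug/mL in this assay, at which 1 of the 3 values shown sits.

The compounds shown leave open whether the sulfur link or the chlorine goes with the lower number; a plain phenylsulfanyl group and a 4-chlorophenyl group joined directly to the ring would separate the two. From the compounds shown here alone, how an amine or a carboxylic acid on this carbon would read also remains open.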